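The source may report more compounds than this note shows. Statements on the series, on what has been measured and on what is new or still open speak of the compounds shown alone.

In a functional assay on A549 cells (Homo sapiens) for antiproliferative activity, with a stated time of 5 days (a higher number here means a weaker inhibitor, a lower number a stronger inhibitor), compound 1 (`CC1OC2(C=CC(=O)C=C2)N(c2nc(-c3ccc4ccccc4c3)nn2-c2ccc3ccccc3c2)C1=O`) gives 300 nM, and compound 2 (`CC1CN(c2nc(-c3ccc4ccccc4c3)nn2-c2ccccc2)C2(C=CC(=O)C=C2)O1`) gives 320 nM, so the two values lie within the scatter of each other. Compound 3 (`Cc1ccc(-n2nc(-c3ccc4ccccc4c3)nc2N2C(=O)C(C)OC23C=CC(=O)C=C3)cc1`) has 4-methylphenyl in place of naphthalen-2-yl on an aromatic nitrogen of the core of compound 1 (4-methylphenyl in place of naphthalen-2-yl on an aromatic nitrogen). Among the measured compounds shown here, no measured pair isolates this change, so only a small shift in this assay is expected, toward a slightly higher number and hardly beyond the scatter. The estimated change is a 1.3-fold higher number from compound 1 to compound 3 (0.10 log units; within the scatter). For compound 3 the expected value is 380 nM, with an estimated range of 150 nM to 950 nM.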

Compound 3, half-maximal inhibitory concentration: 1210 nM
The estimate for compound 3 lay 3.2-fold (0.50 log units) below the measured number, outside the stated range (above it).
By their numbers in this assay, from the lowest: compounds 1 and 2 (each within the scatter of the next); then compound 3.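

In this assay, the aromatic nitrogen of the five-membered ring proves sensitive to the group it carries: 4-methylphenyl in place of naphthalen-2-yl gives a 4.0-fold higher number from compound 1 to compound 3 (0.61 log units; beyond the scatter). This single step cannot separate the loss of the second aromatic ring from the gain of the methyl group. Nothing available accounts for the shift. As far as these compounds go, it remains open whether the unsubstituted phenyl, or a 4-methoxyphenyl or 4-aminophenyl group, at this nitrogen would behave like 4-methylphenyl or like naphthalen-2-yl. From the compounds shown here alone, the same exchange on other cores also remains open.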